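Epoxide Extension of a Flavanone Core

The compounds below may be only part of what the source reports. "The series", "measured", "known", "first", "only" and "open" are said of these compounds alone.

Measured compounds
Compound 1 `COc1cc(O)c2c(c1)O[C@H](c1ccc(O)cc1)C/C2=N\NC(=O)c1ccc(N)cc1`: >= 11300 nM
Compound 2 `COc1ccc([C@@H]2CC(=O)c3c(O)cc(OC)cc3O2)cc1`: >= 11300 nM
Compound 3 `COc1ccc([C@@H]2C/C(=N\Nc3ccc(Br)cn3)c3c(O)cc(OC)cc3O2)cc1`: 8000 nM

Of the compounds shown here, three have been tested in a functional assay on L5178Y cells (Mus musculus) for inhibition, read by MTT assay, with a stated time of 24 h; on this read-out lower numbers stand for stronger inhibition and higher numbers for weaker inhibition. Compound 1 returns only a limit, >= 11300 nM, and not a number. Compound 2 likewise returns only a limit, >= 11300 nM. Compound 3 gives a measured value of 8000 nM. Going by the values given here, compound 2 therefore stands at the boundary of what this assay reports, a position it shares with one other compound; the evidence on the measured set is simply (the limit of >= 11300 nM in this assay, at which 2 of the 3 values shown sit), so no step between measured compounds can be counted, and the reading for compound 3 is the only number in the set.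

Compound 4 `COc1cc(O)c2c(c1)O[C@H](c1ccc(OCC3CO3)cc1)CC2=O` is not yet measured. It is derived from compound 2 by oxiran-2-yl in place of hydrogen on a saturated chain carbon bound to an oxygen on an aromatic ring. Among the compounds with values here, with no measured step to lean on, and with compound 2 itself reported only as a limit, the expectation is for no change beyond the scatter, with a real chance that compound 4 too is reported only as a limit. The expected step is an at least 1.2-fold lower number from compound 2 to compound 4 (0.09 log units; that floor lies within the scatter). Compound 4 is estimated at 9000 nM, in the range 3000 nM to 25000 nM.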

Compound 4, half-maximal inhibitory concentration: >= 11300 nM
Compound 4: no number, only a limit; the forecaster's own chance of this, stated with the estimate: 55%; middle value at least 1.2-fold (0.09 log units) away from the limit.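

In this assay compound 4 returns only a limit (>= 11300 nM) and not a number. Compound 2 is also reported only as a limit, so no step can be read between compound 2 and compound 4: the limit of >= 11300 nM in this assay, at which 3 of the 4 values shown sit. The compounds shown leave open whether oxiran-2-yl in place of hydrogen changes inhibition at all.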